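Swapping piperidin-1-yl for morpholin-4-yl on the sulfonyl sulfur

The source may report more compounds than this note shows. Statements on the series, on what has been measured and on what is new or still open speak of the compounds shown alone.

Values measured in a physicochemical assay for lipophilicity, measured as octanol-water partition, at pH 7.4; a higher number here means a more lipophilic compound, a lower number a more polar compound:
Compound 1 `Cc1ccc2[nH]c(C(=O)N[C@H]3CCN(S(=O)(=O)c4cccnc4)C[C@@H]3C(=O)NCCN(C)C)cc2c1`: 1.3
Compound 2 `Cc1ccc2[nH]c(C(=O)N[C@H]3CCN(S(=O)(=O)C4CC4)C[C@@H]3C(=O)NCCN(C)C)cc2c1`: 1
Compound 3 `Cc1ccc2[nH]c(C(=O)N[C@H]3CCN(S(=O)(=O)N4CCCCC4)C[C@@H]3C(=O)NCCN(C)C)cc2c1`: 2.3

Compound 3 stands highest of the three at 2.3, beyond the scatter of both other compounds. Compound 4 `Cc1ccc2[nH]c(C(=O)N[C@H]3CCN(S(=O)(=O)N4CCOCC4)C[C@@H]3C(=O)NCCN(C)C)cc2c1` carries a single change from compound 3 morpholin-4-yl in place of piperidin-1-yl on a sulfonyl sulfur.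

Among the measured compounds shown here, no measured step makes this exact exchange. The closest evidence comes from the two steps that bring in piperidin-1-yl at the same place, a number 1.00 log units higher from compound 1 to compound 3 (beyond the scatter) and a number 1.30 log units higher from compound 2 to compound 3 (beyond the scatter). In both, the number in this assay rises. The step between the two other groups, a number 0.30 log units lower from compound 1 to compound 2 (within the scatter), is small by comparison. Since compound 4 loses piperidin-1-yl, a fall of modest size, beyond the scatter, is expected, and it should bring the value back towards those of compound 1 and compound 2. The expected step is a number 0.90 log units lower from compound 3 to compound 4 (beyond the scatter). For compound 4 the estimated value is 1.4, with an expected range from 1 to 1.8.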

Compound 4, distribution coefficient: 1
The estimate for compound 4 lay 0.40 log units above the measured number, within the range that was stated.
By their numbers in this assay, from the lowest: compounds 2, 4 and 1 (each within the scatter of the next); then compound 3.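

In this assay the exchange of piperidin-1-yl for morpholin-4-yl keeps the count of six heavy atoms and the link through a sulfonamide nitrogen in a ring, yet it gives a large step (a number 1.30 log units lower from compound 3 to compound 4 (beyond the scatter)). Compound 4 falls in with the two earlier compounds (no change at the digits printed from compound 2 to compound 4 (within the scatter); a number 0.30 log units lower from compound 1 to compound 4 (within the scatter)), so among these four only compound 3 stands apart, and a sulfonamide nitrogen in a ring on the sulfonyl sulfur does not by itself go with the higher number. Nothing measured here accounts for the size of this step.

The compounds shown leave open whether the higher number belongs to piperidin-1-yl specifically or would also come with another group on the sulfonyl sulfur, such as cyclohexyl or an open-chain dimethylamino group. They also leave open where piperazin-1-yl, with its second ring nitrogen in the place of the morpholin-4-yl oxygen, would fall.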